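This account rests on a few compounds, and the source may have more. Where it says the series, first, only, none or still open, it means among the compounds named here.

Compound 1 `COc1cc(-c2cc(/C=C/C(=O)c3ccc(N)cc3)[nH]n2)cc(OC)c1OC` gives 1650 nM in a functional assay on SK-MEL-5 cells (Homo sapiens) for inhibition, read by sulforhodamine B assay, with a stated time of 48 h; on this read-out lower numbers stand for stronger inhibition of growth and higher numbers for weaker inhibition of growth.
Compound 2 `COc1ccc(C(=O)/C=C/c2cc(-c3cc(OC)c(OC)c(OC)c3)n[nH]2)cc1OC` gives 1650 nM in this assay.

In this assay compound 2 stands level with compound 1: the step of no change at the digits printed from compound 1 to compound 2 (within the scatter) shows nothing beyond the usual scatter, so the two values are read as the same. Compound 3 `COc1cc(-c2cc(/C=C/C(=O)c3ccc(F)c(F)c3)[nH]n2)cc(OC)c1OC` has not yet been measured. It differs from compound 2 in one place: 3,4-difluorophenyl in place of 3,4-dimethoxyphenyl on a carbonyl carbon. Among the compounds with values here, the only measured step that bears on this change is the earlier exchange of one aryl group for another on the same carbonyl carbon, no change at the digits printed from compound 1 to compound 2 (within the scatter), which left the growth inhibition unchanged within the scatter. On the strength of that single comparison, the expected outcome for compound 3 is again no step beyond the scatter, no change at the digits printed from compound 2 to compound 3 (within the scatter). The estimate for compound 3 is therefore 1650 nM, with a range from 600 nM to 4500 nM.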

Compound 3, concentration for 50% growth inhibition: 2270 nM
Estimate against measurement, compound 3: 1.4-fold (0.14 log units) below, and the stated range covers the measured number.
By their numbers in this assay, from the lowest: compounds 1, 2 and 3 (each within the scatter of the next).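

On the carbonyl carbon, the 3,4-difluorophenyl group replaces the 3,4-dimethoxyphenyl group, and this assay shows only a 1.4-fold higher number from compound 2 to compound 3 (0.14 log units; within the scatter) in growth inhibition. Set against the 4-aminophenyl group, the same exchange gives a 1.4-fold higher number from compound 1 to compound 3 (0.14 log units; within the scatter), so three differently substituted phenyl rings now read alike, including one whose substituents have no hydrogen-bond acceptors by the count for this change. Nothing at hand explains why these exchanges leave the value within the scatter.

As far as these compounds go, all three groups at this position are substituted phenyl rings, so it remains open whether a ring carrying a carboxylic acid would read the same. From the compounds shown here alone, it also remains open whether a non-aromatic group such as cyclohexyl or a longer alkyl chain would keep the value.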